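The source may hold more compounds than are shown below. What is called first, only, known or untested is meant among the compounds shown, and "the series" means these compounds.

Measured so far in an ADME assay on a cell-free system (plasma, Mus musculus) for metabolic stability, read by LC-MS, tested at 2 uM; a higher number here means that the compound lasts longer, a lower number that the compound disappears faster:
- compound 1, `O=C(NCCCCc1ccccc1)n1c2c(oc1=O)CNCC2`, gives > 2 h, a limit of this assay rather than a number.
- compound 2, `CN1CCC(c2ccc3c(c2)oc(=O)n3C(=O)NCCOCc2ccccc2)CC1`, gives 0.667 h.
- compound 3, `CC(C)CNC(=O)n1c(=O)oc2ccc(C3CCN(C)CC3)cc21`, gives 0.5 h.

Compound 2 holds the higher of the two numbers, yet its gap to compound 3 is within the scatter, so no order between them is claimed. Compound 1 stands at the assay limit (the limit of > 2 h in this assay, at which 1 of the 3 values shown sits).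

Compound 4, `CN1CCC(c2ccc3c(c2)oc(=O)n3C(=O)NCCCCc2ccccc2)CC1`, differs from compound 2 in one place: phenethyl in place of benzyloxy on a saturated chain carbon, two bonds along the chain from an amide-type nitrogen. Among the measured compounds shown here, no pair of measured compounds isolates this change, so the expectation rests on compound 2 alone. The step is expected to be a 1.2-fold higher number from compound 2 to compound 4 (0.08 log units; within the scatter). Compound 4 is therefore estimated at 0.8 h, in the range 0.35 h to 2 h.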

Compound 4, half-life: 0.833 h
Compound 4: middle estimate off by 1.0-fold (0.02 log units), on the low side; the range from low to high includes it.
By their numbers in this assay, from the lowest: compounds 3, 2 and 4 (each within the scatter of the next). At a limit, above all of these: compound 1.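

In this assay, phenethyl in place of benzyloxy on a saturated chain carbon, two bonds along the chain from an amide-type nitrogen, gives a 1.2-fold higher number from compound 2 to compound 4 (0.10 log units; within the scatter). This first measured step at the position shows that exchanging the chain oxygen of benzyloxy for carbon does not separate the two compounds in this read-out. Nothing shown gives a cause for this step. Going by these compounds, whether an amine or a carboxylic acid at this place would give a half-life beyond the scatter remains open, as does whether this step would hold on another core.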